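Fluoro for chloro on the fused benzene of compound 2

The source may report more compounds than this note shows. Statements on the series, on what has been measured and on what is new or still open speak of the compounds shown alone.

Compound 1, `O=C(O)Cn1c(=O)c(Oc2cc(O)cc(O)c2)nc2ccccc21`: 46.5%
Compound 2, `O=C(O)Cn1c(=O)c(Oc2cc(O)cc(O)c2)nc2ccc(Cl)cc21`: 83.7%

In a physicochemical assay, read by spectrophotometry, with a stated time of 240 min, tested at 50 uM (on this read-out higher numbers stand for a stronger effect at the one concentration tested and lower numbers for a weaker effect), compound 2 stands highest of the two numbers, and its nearest neighbour is compound 1, which lies a number 37.2 percentage points higher from compound 1 to compound 2 (beyond the scatter). Compound 3, `O=C(O)Cn1c(=O)c(Oc2cc(O)cc(O)c2)nc2ccc(F)cc21`, differs from compound 2 by fluoro in place of chloro on an aromatic carbon. Among the compounds with values here, the only step measured so far, the one from hydrogen to chloro, was large; fluoro is expected to keep part of that gain rather than fall back to compound 1, since the halogen stays on the same aromatic carbon. Compound 3 is therefore estimated at 65%, within 48% to 82%. The expected step is a number 18.7 percentage points lower from compound 2 to compound 3 (beyond the scatter), downward but beyond the scatter only narrowly.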

Compound 3, a percentage reported as activity, at one concentration (the size of the read-out at that concentration, not a potency): 29.3%
Compound 3: middle estimate off by 35.7 percentage points, on the high side, outside the stated range (below it).
By their numbers in this assay, from the lowest: compound 3; then compound 1; then compound 2.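

In this assay, the two halogens on this aromatic carbon do not behave as one kind of change: the record shows a number 54.4 percentage points lower from compound 2 to compound 3 (beyond the scatter), and also a number 17.2 percentage points lower from compound 1 to compound 3 (beyond the scatter). Fluoro in compound 3 therefore falls on the opposite side of the unsubstituted compound 1 from chloro in compound 2, so the gain seen with chloro does not extend to halogens in general here. Nothing available explains why the two halogens part so widely.

Going by these compounds, whether bromo or methoxy on the same carbon would rise with chloro or sink with fluoro remains open. Also open, on these data alone, is whether the chloro gain would hold at the other positions of that ring.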